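Replacing the chloro of compound 2 with (dimethylamino)methyl

The compounds below may be only part of what the source reports. "The series", "measured", "known", "first", "only" and "open" are said of these compounds alone.

Of the compounds shown here, three sharing one core have been measured in a functional assay on MCF7 cells (Homo sapiens) for cytotoxicity, read by neutral red uptake, with a stated time of 3 days; a lower number here means a stronger inhibitor, a higher number a weaker inhibitor. Compound 1 `Cc1c(F)c(N)c2c(=O)cc(-c3ccc(N)c(F)c3)oc2c1F` gives 13 nM in this assay, compound 2 `Nc1ccc(-c2cc(=O)c3c(N)c(F)c(Cl)c(F)c3o2)cc1F` gives 210 nM, and compound 3 `CN(C)c1c(F)c(N)c2c(=O)cc(-c3ccc(N)c(F)c3)oc2c1F` gives 39 nM. Compound 2 stands highest of the three: the nearest is compound 3, with a 5.4-fold lower number from compound 2 to compound 3 (0.73 log units; beyond the scatter), and the furthest is compound 1, with a 16-fold higher number from compound 1 to compound 2 (1.21 log units; beyond the scatter).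

The step from compound 2 to compound 4 `CN(C)Cc1c(F)c(N)c2c(=O)cc(-c3ccc(N)c(F)c3)oc2c1F` is (dimethylamino)methyl in place of chloro on an aromatic carbon. Going by the values given here, two measured steps bear on it. The exchange of chloro for dimethylamino produced a 5.4-fold lower number from compound 2 to compound 3 (0.73 log units; beyond the scatter), and chloro in place of methyl produced a 16-fold higher number from compound 1 to compound 2 (1.21 log units; beyond the scatter); both show that compound 2 carries the least favourable group at this carbon among the groups tried. Among the compounds with values here, the (dimethylamino)methyl group contains the same nitrogen as the dimethylamino of compound 3, but on a further carbon, which none of the measured compounds tests. Compound 4 is therefore expected to give a lower number than compound 2, with a step of about a 4.2-fold lower number from compound 2 to compound 4 (0.62 log units; beyond the scatter), resting on the measured result of compound 3 39 nM. The estimate for compound 4 in this assay is 50 nM, within a range from 12 nM to 200 nM.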

Compound 4, half-maximal inhibitory concentration: 72 nM
Beside the measured number, compound 4's estimate is 1.4-fold (0.16 log units) below it; the range from low to high includes it.
By their numbers in this assay, from the lowest: compound 1; then compounds 3 and 4 (each within the scatter of the next); then compound 2.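

In this assay the (dimethylamino)methyl group also outperforms chloro on this aromatic carbon, with a 2.9-fold lower number from compound 2 to compound 4 (0.46 log units; beyond the scatter) showing that the gain seen with dimethylamino does not require the nitrogen to sit directly on the ring. Placing a carbon before that nitrogen leaves compound 3 and compound 4 level, since a 1.8-fold higher number from compound 3 to compound 4 (0.27 log units; within the scatter) does not separate them. Putting dimethylamino on the methyl group of compound 1 is a loss, with a 5.5-fold higher number from compound 1 to compound 4 (0.74 log units; beyond the scatter) leaving the plain methyl group ahead of the longer substituent at this carbon.

The compounds shown leave open how an ethyl group, a methoxy group or a morpholine ring attached through the same single carbon would stand at this position. Nothing shown gives a reason for any of these differences.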